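A Ring Swap on Compound 1

The source may report more compounds than this note shows. Statements on the series, on what has been measured and on what is new or still open speak of the compounds shown alone.

In an ADME assay on microsomes from liver (Mus musculus) for metabolic stability, read by LC-MS, using NADPH, with a stated time of 60 min, tested at 0.1 uM (a lower number here means that less of the compound is left, a higher number that more of the compound is left), compound 1 `Fc1ccc(Nc2cc3[nH]c(Nc4cc(N5CCNCC5)ccn4)nc3cn2)cc1C(F)(F)F` gives 78% and compound 2 `C[C@@H]1CN(c2ccc(Nc3nc4cnc(Nc5ccc(F)c(F)c5)cc4[nH]3)nc2)C[C@H](C)N1` gives 76% and the two numbers lie within the usual scatter of each other. Compound 3 `FC1(F)CC(Nc2cc3[nH]c(Nc4ccc(N5CCN(CC6CC6)CC5)cn4)nc3cn2)C1` gives 54% and so falls short of compound 1 by more than the scatter.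

Compound 4 `C[C@@H]1CN(C(=O)c2ccnc(Nc3nc4cnc(Nc5ccc(F)c(C(F)(F)F)c5)cc4[nH]3)c2)C[C@H](C)O1` has not been measured yet. It differs from compound 1 in one place: (2,6-dimethylmorpholin-4-yl)carbonyl stands in place of piperazin-1-yl on an aromatic carbon, opposite the ring nitrogen (2,6-dimethylmorpholin-4-yl)carbonyl in place of piperazin-1-yl on an aromatic carbon and the rest of the structure stays the same.

For the measured compounds named here, no two measured compounds differ in just one place, so no measured step speaks directly to this change, and none of the three carries a carbonyl there. Going by the values given here, the only guide is the spread of the values, which shows with compound 3 at 54% that a different side group can go with a clearly lower number than compound 1 at 78% in this series. A fall beyond the scatter is therefore expected, though with wide uncertainty, and the estimated step of a number 20 percentage points lower from compound 1 to compound 4 (beyond the scatter) reflects that. For compound 4 the estimated value is 58% with an expected range from 32% to 80% in this assay for now.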

Compound 4, percent of the compound remaining: 41%
Estimate against measurement, compound 4: 17 percentage points above, and the stated range covers the measured number.
By their numbers in this assay, from the lowest: compound 4; then compound 3; then compounds 2 and 1 (each within the scatter of the next).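

For the compounds shown here, this is the first step that can be read at this position: in this assay, putting (2,6-dimethylmorpholin-4-yl)carbonyl in place of piperazin-1-yl, opposite the ring nitrogen, goes with a number 37 percentage points lower from compound 1 to compound 4 (beyond the scatter). With the rest of the structure unchanged, this one swap is enough to leave clearly less of the compound, so the position is not indifferent to the group it carries. The entering group is larger and has a carbonyl and no hydrogen-bond donor, but nothing measured here says which of these differences, if any, lies behind the fall.

The step changes the ring and adds the carbonyl at once, so the compounds shown cannot separate the two: a plain morpholin-4-yl ring on the same carbon, or a piperazin-1-ylcarbonyl group, would each carry only one part of the change. They also leave open what the two methyl groups on the ring contribute, and how a simple amine or a carboxylic acid would read at this position.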